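The source may hold more compounds than are shown below. What is called first, only, known or untested is meant among the compounds shown, and "the series" means these compounds.

Measured so far:
compound 1, `CC1(C)N=C(N)N=C(N)N1c1ccccc1N`, 3.41
compound 2, `CC1(C)N=C(N)N=C(N)N1c1ccccc1O`, 2.92

Compound 1 carries an amino group on the aromatic ring; compound 2, the hydroxy analogue, is the weaker of the two in an assay on isolated protein for inhibition of Dihydrofolate reductase (Mus musculus), at pH 7.20; a higher number here means a more potent compound, by a factor of ten per unit of this negative logarithm, a lower number a less potent compound. Among the compounds with values here, the only comparison at hand is a number 0.49 log units lower from compound 1 to compound 2 (beyond the scatter), so compound 2 stands at the lower of the two numbers known for this series. Compound 3, `CC1(C)N=C(N)N=C(N)N1c1ccccc1C(F)(F)F`, is the next member to be measured. It differs from compound 2 in a single respect: trifluoromethyl in place of hydroxy on an aromatic carbon. Within the data shown here, no measured step involves a trifluoromethyl group, so the one known step, amino to hydroxy, bears on the new change only indirectly, by showing that exchanging the group at this position moves the read-out by a modest amount. Without a closer precedent, compound 3 is expected to land near the two known values, somewhat above compound 2, with wide uncertainty in either direction. The estimated value for compound 3 in this assay is 3.7, with a range from 2.9 to 4.5, which corresponds to an expected step of a number 0.78 log units higher from compound 2 to compound 3 (beyond the scatter).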

Compound 3, logarithm of the reciprocal of the active concentration, log(1/C): 3.03
Estimate against measurement, compound 3: 0.67 log units above, and the stated range covers the measured number.
By their numbers in this assay, from the lowest: compounds 2 and 3 (each within the scatter of the next); then compound 1.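

In this assay, the exchange of hydroxy for trifluoromethyl on this aromatic carbon gives a number 0.11 log units higher from compound 2 to compound 3 (within the scatter), so two groups that differ in heavy atoms and in hydrogen-bond donors and acceptors cannot be told apart here. Compound 1 now stands apart from both other compounds: alongside a number 0.49 log units lower from compound 1 to compound 2 (beyond the scatter), the new comparison gives a number 0.38 log units lower from compound 1 to compound 3 (beyond the scatter), so in this small set both replacements of amino give a lower number, each by a modest amount. No further data on these compounds bear on why the numbers fall this way.

On these data alone, it remains open whether the higher number belongs to amino alone or would also appear with a methylamino group, an acetamide or a carboxylic acid at this place, and whether a plain methyl group or a chlorine atom would instead read like compound 2 and compound 3. Also open, as far as these compounds go, is whether these exchanges would give similar steps on a core other than the shared core of these three compounds.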